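The compounds below may be only part of what the source reports. "The series", "measured", "known", "first", "only" and "open" are said of these compounds alone.

Compound 1 `COc1cc(C(=O)c2cn(-c3ccccc3)cc2-c2ccc(N)cc2)cc(OC)c1OC`: 9 nM
Compound 2 `COc1cc(C(=O)c2cn(-c3ccccc3)cc2-c2ccccc2C)cc(OC)c1OC`: 190 nM
Compound 3 `COc1cc(C(=O)c2cn(-c3ccccc3)cc2-c2ccc(Cl)cc2)cc(OC)c1OC`: 290 nM

In a functional assay on MCF7 cells (Homo sapiens) for cytotoxicity, read by MTT assay, with a stated time of 96 h (on this read-out higher numbers stand for weaker inhibition and lower numbers for stronger inhibition), compound 3 gives 290 nM. This places it level with compound 2 within the scatter, as a 1.5-fold higher number from compound 2 to compound 3 (0.18 log units; within the scatter) shows, and far from compound 1, as a 32-fold higher number from compound 1 to compound 3 (1.51 log units; beyond the scatter) shows.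

The next compound is compound 4 `COc1cc(C(=O)c2cn(-c3ccccc3)cc2-c2cccc(Br)c2)cc(OC)c1OC`, which carries 3-bromophenyl in place of 4-chlorophenyl on an aromatic carbon. Among the compounds with values here, no measured step makes this exact exchange, and none shows what a bromo group does on this ring.

The closest evidence is the exchange of 4-chlorophenyl for 2-methylphenyl, seen in a 1.5-fold higher number from compound 2 to compound 3 (0.18 log units; within the scatter), which stayed within the scatter. The two large steps, a 21-fold higher number from compound 1 to compound 2 (1.32 log units; beyond the scatter) and a 32-fold higher number from compound 1 to compound 3 (1.51 log units; beyond the scatter), both start from the 4-aminophenyl compound. Compound 4 has no amino group, so they bear on it only weakly, and three compounds are a thin basis.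

On these data alone, no step beyond the scatter is therefore expected in this assay, and the direction stays open. The expected step is a 1.3-fold lower number from compound 3 to compound 4 (0.12 log units; within the scatter). For compound 4 the estimated value is 220 nM, with an expected range from 70 nM to 700 nM.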

Compound 4, half-maximal inhibitory concentration: 950 nM
Estimate against measurement, compound 4: 4.3-fold (0.64 log units) below; the whole stated range lies below it.
By their numbers in this assay, from the lowest: compound 1; then compounds 2 and 3 (each within the scatter of the next); then compound 4.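

In this assay, this position proved less forgiving among the groups without an amino group than compounds 2 and 3 had suggested: the exchange to 3-bromophenyl gives steps beyond the scatter (a 3.3-fold higher number from compound 3 to compound 4 (0.52 log units; beyond the scatter); a 5.0-fold higher number from compound 2 to compound 4 (0.70 log units; beyond the scatter)), whereas the exchange between 2-methylphenyl and 4-chlorophenyl stayed within it. Compound 4 is thus the weakest of the four, and the gap to the 4-aminophenyl compound is the widest seen at this position (a 110-fold higher number from compound 1 to compound 4 (2.02 log units; beyond the scatter)), which sets that group still further apart from the other three. No measured evidence among the data shown accounts for this result.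

The exchange from compound 3 to compound 4 alters both the halogen and its place on the phenyl ring at once, so the compounds shown cannot separate the two, and a 4-bromophenyl or a 3-chlorophenyl group would be needed to do that. They also leave open whether a 3-aminophenyl or a 4-hydroxyphenyl group would keep the low number of compound 1 (9 nM).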